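The source may report more compounds than this note shows. Statements on the series, on what has been measured and on what is new or still open speak of the compounds shown alone.

Values in a functional assay on HT cells (Homo sapiens) for antiproliferative activity, read by fluorescence, with a stated time of 72 h; a higher number here means a weaker inhibitor of growth, a lower number a stronger inhibitor of growth:
- compound 1 `CC(C)c1n[nH]c2c(NCc3ccc(-c4ccccn4)cc3)nc(SCC3CNC(=O)O3)nc12`: 80 nM
- compound 2 `CC(C)c1n[nH]c2c(NCc3ccc(-c4ccccn4)cc3)nc(SCC(O)CN3CCNCC3)nc12`: 332 nM
- compound 3 `CC(C)c1n[nH]c2c(NCc3ccc(-c4ccccn4)cc3)nc(SC(C)C(C)O)nc12`: 190 nM

Compound 3 lies within the scatter of its nearest neighbour, a 1.7-fold lower number from compound 2 to compound 3 (0.24 log units; within the scatter), while its gap to the lowest number is a 2.4-fold higher number from compound 1 to compound 3 (0.38 log units; beyond the scatter). Compound 4 `CC(C)c1n[nH]c2c(NCc3ccc(-c4ccccn4)cc3)nc(SCCNC(N)=O)nc12` carries 2-ureidoethyl in place of 2-hydroxy-1-methylpropyl on a sulfur.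

Among the compounds with values here, no measured step holds this exact swap. The changes on that sulfur are modest, a 2.4-fold higher number from compound 1 to compound 3 (0.38 log units; beyond the scatter) and a 4.2-fold higher number from compound 1 to compound 2 (0.62 log units; beyond the scatter), so only a small step is expected in this assay. The direction is tentatively downward, as the entering ureido group has a carbonyl, as does the oxazolidinone of compound 1 at 80 nM. The expected move is a 1.5-fold lower number from compound 3 to compound 4 (0.16 log units; within the scatter). For compound 4 the estimated value is 130 nM, with an expected range of 55 nM to 310 nM.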

Compound 4, concentration for 50% growth inhibition: 240 nM
Compound 4: the middle estimate sits 1.8-fold (0.27 log units) below what was measured; the measured number falls inside the stated range.
By their numbers in this assay, from the lowest: compound 1; then compounds 3, 4 and 2 (each within the scatter of the next).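

On the sulfur, 2-ureidoethyl in this assay gives a number within the scatter of both open-chain compounds (a 1.3-fold higher number from compound 3 to compound 4 (0.10 log units; within the scatter); a 1.4-fold lower number from compound 2 to compound 4 (0.14 log units; within the scatter)). Compound 1 alone stands apart (a 3.0-fold higher number from compound 1 to compound 4 (0.48 log units; beyond the scatter)), so a carbonyl in the side chain does not by itself go with the lowest number, since compound 4 also carries one. No measurement available here accounts for that gap.

Open, on these data alone, is whether a carboxylic acid or a primary amine at the end of the ethyl chain would fall in the same range. Also open, as far as these compounds go, is how a longer chain bearing the ureido group would compare.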